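A few compounds are considered here, and "the series" means these few. Any claim that something is new, unique, unknown or untested is made for them only; others in the source may bear on it.

Series notes. In a functional assay on MGC-803 cells (Homo sapiens) for antiproliferative activity, read by CCK-8 assay, with a stated time of 72 h, tested at 2 uM (a lower number here means a weaker effect, a higher number a stronger effect of the compound at the concentration tested), compound 1 `CN(C(=S)SCc1ccc(C(=O)Nc2ccccc2N)cc1)c1cccnc1` gives 46.1%. Among the measured compounds shown here, compound 2 `Nc1ccccc1NC(=O)c1ccc(CSC(=S)N2CCN(Cc3ccncc3)CC2)cc1` gives 18.4% in this assay, the second highest of the three numbers so far: its nearest neighbour is compound 3 `Nc1ccccc1NC(=O)c1ccc(CSC(=S)N(Cc2ccccc2)Cc2ccccc2)cc1`, which gives 11% in this assay, a gap within the scatter, while compound 1 stands beyond the scatter above it.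

Compound 4 `Nc1ccccc1NC(=O)c1ccc(CSC(=S)N2CCN(Cc3ccccc3)CC2)cc1` is the next point, derived from compound 2 by phenyl in place of pyridin-4-yl on a saturated chain carbon bound to an amine nitrogen in a ring. For the measured compounds named here, no step between measured compounds reads on this change directly. Compound 3 carries benzyl groups and its number sits within the scatter of compound 2, so the step from compound 2 to compound 4 is expected to be a number 2.4 percentage points lower from compound 2 to compound 4 (within the scatter), nothing beyond the scatter in either direction. Compound 4 is therefore estimated at 16% in this assay, in the range 5% to 30%.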

Compound 4, a percentage reported as inhibition, at one concentration (the size of the read-out at that concentration, not a potency): 18.1%
Compound 4: middle estimate off by 2.1 percentage points, on the low side; low and high end bracket the measured number.
By their numbers in this assay, from the lowest: compounds 3, 4 and 2 (each within the scatter of the next); then compound 1.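

In this assay, among the compounds shown here, a number 0.3 percentage points lower from compound 2 to compound 4 (within the scatter), the first direct reading of this change: on a saturated chain carbon bound to an amine nitrogen in a ring, phenyl and pyridin-4-yl are not told apart at the concentration tested. The hydrogen-bond acceptor counted on pyridin-4-yl can therefore be lost here without a step beyond the scatter. Nothing on hand explains why the two groups read alike. Still open, on these data alone, is whether a different group at this place, such as a carboxylic acid or a primary amine on the phenyl, would shift the number.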